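This account rests on a few compounds, and the source may have more. Where it says the series, first, only, none or still open, it means among the compounds named here.

Measured so far in a functional assay on RAW264.7 cells (Mus musculus) for inhibition, with stated times of 2 h and 24 h; a lower number here means a stronger inhibitor, a higher number a weaker inhibitor:

Compound 1 `COc1ccc([C@@H]2c3c(OC)cc(OC)cc3C(O)[C@H]2c2cc(OC)cc(OC)c2)cc1`: 7870 nM
Compound 2 `COc1ccc(CSC2c3cc(OC)cc(OC)c3[C@@H](c3ccc(OC)cc3)[C@@H]2c2cc(OC)cc(OC)c2)cc1`: 12500 nM
Compound 3 `COc1ccc([C@@H]2c3c(OC)cc(OC)cc3C(SCc3ccccc3)[C@H]2c2cc(OC)cc(OC)c2)cc1`: > 200000 nM

The entry for compound 3 is a limit of the assay and not a number. Compound 3 is the weakest of the three, with an at least 25-fold higher number from compound 1 to compound 3 (1.40 log units; beyond the scatter) and an at least 16-fold higher number from compound 2 to compound 3 (1.20 log units; beyond the scatter). Compound 4 `COc1ccc([C@@H]2c3c(OC)cc(OC)cc3C(SCc3ccc(C)cc3)[C@H]2c2cc(OC)cc(OC)c2)cc1` departs from compound 3 by methyl in place of hydrogen on an aromatic carbon, turning benzylsulfanyl into (4-methylbenzyl)sulfanyl.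

Within the data shown here, the step most relevant here is the one that ties compound 2 to compound 3, a large one, where hydrogen replaces methoxy on that same carbon. Also relevant is a 1.6-fold higher number from compound 1 to compound 2 (0.20 log units; within the scatter), which shows that the sulfanyl group carrying methoxy keeps pace with hydroxy. Methyl is not methoxy, so only part of that large step is expected to return, and a lower number than the limit of compound 3 is expected in this assay. The expected step is an at least 5.0-fold lower number from compound 3 to compound 4 (0.69 log units; beyond the scatter). For compound 4 the estimate is 40000 nM, with an expected range of 12000 nM to 200000 nM.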

Compound 4, half-maximal inhibitory concentration: > 200000 nM
Compound 4: a limit, no number; the forecaster's own chance of this, stated with the estimate: 30%; middle value at least 5.0-fold (0.69 log units) from the limit.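

In this assay compound 4 gives > 200000 nM as a limit of the assay and not a number. The step between compound 3 and compound 4 cannot be read, because both entries sit at the same limit: the limit of > 200000 nM in this assay, at which 2 of the 4 values shown sit. Methyl does not match methoxy on this aromatic carbon, for methyl in place of methoxy gives an at least 16-fold higher number from compound 2 to compound 4 (1.20 log units; beyond the scatter) and (4-methylbenzyl)sulfanyl in place of hydroxy gives an at least 25-fold higher number from compound 1 to compound 4 (1.40 log units; beyond the scatter) in this series, so among the sulfanyl compounds shown only compound 2 stays within the scatter of compound 1.

The compounds shown leave open how far past the limit compound 3 and compound 4 lie, and so whether methyl changes anything at all. They also leave open whether another group on this carbon, such as an amine or a carboxylic acid, would bring the number back towards that of compound 2.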